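The compounds below may be only part of what the source reports. "The series", "measured", "known", "first", "only" and "open" are said of these compounds alone.

The series shares one core, seen in compound 1 `CCN(CC)CCNS(=O)(=O)c1ccc(-c2ccnc3[nH]ccc23)cc1` and compound 2 `O=S(=O)(NCCN1CCCCC1)c1ccc(-c2ccnc3[nH]ccc23)cc1`, both carrying a sulfonamide with a side chain. Among the compounds with values here, in an assay on isolated protein for inhibition of serine/threonine-protein kinase Nek1 (Homo sapiens), read by TR-FRET, with a stated time of 30 min (on this read-out lower numbers stand for stronger inhibition and higher numbers for weaker inhibition), compound 1 gives 10000 nM, and in the same assay compound 2 gives 6600 nM; the only measured step, a 1.5-fold lower number from compound 1 to compound 2 (0.18 log units; within the scatter), changes the amine two bonds along the chain from the sulfonamide nitrogen and stays within the scatter. In this assay compound 3 `CC(C)(C)OC(=O)NCCNS(=O)(=O)c1ccc(-c2ccnc3[nH]ccc23)cc1` gives no result reported, so its standing cannot be placed on the shown data. Compound 4 `COCCNS(=O)(=O)c1ccc(-c2ccnc3[nH]ccc23)cc1` is obtained from compound 3 by the change (methoxy in place of (tert-butoxycarbonyl)amino on a saturated chain carbon, two bonds along the chain from a sulfonamide nitrogen), a replacement at the same place along the chain where compound 1 and compound 2 already differ. Within the data shown here, with compound 3 unmeasured, no step to compound 4 can be sized; the closest guide is that compounds 1 and 2 both sit at weak inhibition and their step lies within the scatter. Compound 4 is therefore expected to give about 10000 nM in this assay, with a range from 3000 nM to 30000 nM.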

Compound 4, half-maximal inhibitory concentration: > 30000 nM
Compound 4: a limit, no number; the forecaster's own chance of this, stated with the estimate: 40%; middle value at least 3.0-fold (0.47 log units) from the limit.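

In this assay compound 4 gives > 30000 nM, which is a limit of the assay and not a number: the limit of > 30000 nM in this assay, at which 1 of the 4 values shown sits. The place two bonds along the chain from a sulfonamide nitrogen, where the earlier exchange of one amine for another stayed within the scatter, now shows steps beyond it: methoxy in place of piperidin-1-yl gives an at least 4.5-fold higher number from compound 2 to compound 4 (0.65 log units; beyond the scatter), and methoxy in place of diethylamino gives an at least 3.0-fold higher number from compound 1 to compound 4 (0.47 log units; beyond the scatter). Both steps run the same way, so among these three compounds the two carrying a tertiary amine on the chain read lower than the one carrying methoxy, and the full size of either step stays unknown.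

As far as these compounds go, whether a primary amine, a carboxylic acid or a longer chain at this place would read nearer compound 2 or compound 4 remains open. Steps to or from compound 3 cannot be read.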